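Dimethylamino to Cyano: Estimating Compound 3

The source may hold more compounds than are shown below. What is called first, only, known or untested is meant among the compounds shown, and "the series" means these compounds.

compound 1 `CCCCCCCCCCCCCCCCCCNC(=O)[C@H]1CSC(c2c[nH]c3ccccc23)N1`: 8900 nM
compound 2 `CCCCCCCCCCCCCCCCCCNC(=O)[C@H]1CSC(c2ccc(N(C)C)cc2)N1`: 5300 nM

In a functional assay on DU-145 cells (Homo sapiens) for antiproliferative activity, read by sulforhodamine B assay (on this read-out higher numbers stand for weaker inhibition and lower numbers for stronger inhibition), compound 2 gives 5300 nM, the smaller of the two numbers measured, while compound 1 gives 8900 nM. Among the compounds with values here, the only measured step, a 1.7-fold lower number from compound 1 to compound 2 (0.23 log units; within the scatter), lies within the scatter, so the two compounds cannot be separated on this read-out. Compound 3 `CCCCCCCCCCCCCCCCCCNC(=O)[C@H]1CSC(c2ccc(C#N)cc2)N1` differs from compound 2 by cyano in place of dimethylamino on an aromatic carbon. Within the data shown here, no measured step exchanges one substituent for another on the aromatic ring; the step from compound 1 to compound 2 replaced the whole group on the saturated ring carbon and produced no change beyond the scatter, so it bears only loosely on the present change. Compound 3 is therefore expected to stay near compound 2 in this assay, an estimated 6000 nM with a range of 2500 nM to 15000 nM. The expected step of a 1.1-fold higher number from compound 2 to compound 3 (0.05 log units; within the scatter) is not anticipated to exceed the scatter.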

Compound 3, half-maximal inhibitory concentration: > 20000 nM
Compound 3: a limit, no number; the forecaster's own chance of this, stated with the estimate: 5%; middle value at least 3.3-fold (0.52 log units) from the limit.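

Compound 3 stands at a limit of the assay, not at a number: the limit of > 20000 nM in this assay, at which 1 of the 3 values shown sits. Even so, this assay now separates compounds in this series: on an aromatic carbon para to a large group, cyano in place of dimethylamino gives an at least 3.7-fold higher number from compound 2 to compound 3 (0.57 log units; beyond the scatter), so a change at this one position moves the read-out beyond the scatter, which the earlier pair did not show. Within the data shown here, exchanging the whole group on the saturated ring carbon, 4-cyanophenyl in place of 1H-indol-3-yl, likewise gives an at least 2.2-fold higher number from compound 1 to compound 3 (0.35 log units; beyond the scatter), unlike the step between the earlier compounds.

On these data alone, how far compound 3 lies past its limit stays unknown, so both steps have only a lower bound. As far as these compounds go, whether other groups at this position, such as a primary amine, a methoxy group or a carboxylic acid, would stay near compound 2 or follow compound 3 remains open.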